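The source may hold more compounds than are shown below. What is called first, only, known or untested is meant among the compounds shown, and "the series" means these compounds.

Measured so far:
compound 1, `COc1cc(OC)cc(C(=O)NC2CCN(Cc3ccc4ccccc4c3)CC2)c1`: 27 nM in an assay on isolated protein for binding affinity to melanin-concentrating hormone receptor 1 (Homo sapiens); a higher number here means a weaker inhibitor, a lower number a stronger inhibitor
compound 2, `O=C(NC1CCN(Cc2ccc3ccccc3c2)CC1)c1ccc(F)c(F)c1`: 18 nM in this assay

Compound 2 holds the lower of the two numbers in this assay; its nearest neighbour is compound 1, and the gap between them, a 1.5-fold lower number from compound 1 to compound 2 (0.18 log units; within the scatter), lies within the scatter, so no order between compound 1 and compound 2 can be read from it. Compound 3, `CN(C)c1cccc(C(=O)NC2CCN(Cc3ccc4ccccc4c3)CC2)c1`, is not yet measured. It differs from compound 2 in one place: 3-(dimethylamino)phenyl in place of 3,4-difluorophenyl on a carbonyl carbon. Going by the values given here, the only measured step that bears on this change is the earlier exchange of the ring on the carbonyl carbon, a 1.5-fold lower number from compound 1 to compound 2 (0.18 log units; within the scatter), which stayed within the scatter. With yet another ring entering at the same place, no step beyond the scatter is expected in this assay for compound 3, in either direction. The estimate for compound 3 is 25 nM, with a range from 8 nM to 80 nM. This would mean an expected 1.4-fold higher number from compound 2 to compound 3 (0.14 log units; within the scatter), itself within the scatter.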

Compound 3, inhibition constant: 125 nM
The estimate for compound 3 lay 5.0-fold (0.70 log units) below the measured number; measured number above the stated range.
By their numbers in this assay, from the lowest: compounds 2 and 1 (each within the scatter of the next); then compound 3.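

In this assay the group on the carbonyl carbon turns out not to be interchangeable: 3-(dimethylamino)phenyl in place of 3,4-difluorophenyl gives a 6.9-fold higher number from compound 2 to compound 3 (0.84 log units; beyond the scatter) and in place of 3,5-dimethoxyphenyl gives a 4.6-fold higher number from compound 1 to compound 3 (0.67 log units; beyond the scatter), while the earlier exchange at this place, a 1.5-fold lower number from compound 1 to compound 2 (0.18 log units; within the scatter), stayed within the scatter. Of the three rings shown, 3-(dimethylamino)phenyl alone stands apart, with the weaker number, and the other two cannot be ordered. Nothing at hand explains the size of this step.

As far as these compounds go, it remains open whether the step follows the dimethylamino group itself or any replacement of the fluorines and methoxy groups by a single substituent. A phenyl ring carrying one methoxy group or a primary amine in place of the dimethylamino group would separate these readings.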